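The compounds below may be only part of what the source reports. "The series", "measured", "known", "first", "only" and "open" are said of these compounds alone.

Measured so far in an ADME assay on HEp-2 cells (Homo sapiens) for cytotoxicity; on this read-out higher numbers stand for lower toxicity in this test and lower numbers for higher toxicity in this test:

Compound 1 `Cc1ccc(NC(=O)CNS(=O)(=O)c2cccc3cccnc23)c(C)c1`: > 50000 nM
Compound 2 `CCc1ccccc1NC(=O)[C@@H]1CCCN1S(=O)(=O)c1cccc2cccnc12`: > 50000 nM

Compound 2 stands at the limit of > 50000 nM in this assay, at which 2 of the 2 values shown sit. Its reading is a limit of the assay and not a number. Compound 1 sits at that same limit.

Compound 3 `Cc1cc(C)cc(NC(=O)[C@@H]2CCCN2S(=O)(=O)c2cccc3cccnc23)c1` has not yet been measured. It keeps the core of compound 2 and changes the group on the amide-type nitrogen: 3,5-dimethylphenyl in place of 2-ethylphenyl on an amide-type nitrogen. Here 3,5-dimethylphenyl takes the place of 2-ethylphenyl, so the same atoms are joined differently.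

Among the compounds with values here, no measured step between compounds differing in one place is available as a guide. Within the data shown here, the only anchor is that compound 2 gives the limit > 50000 nM, so no change beyond the scatter is expected, in either direction. The expected change is a step that the limit leaves unreadable from compound 2 to compound 3. For compound 3 the estimated value is 60000 nM, with an expected range from 25000 nM to 100000 nM.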

Compound 3, half-maximal cytotoxic concentration: 31300 nM
Compound 3: the middle estimate sits 1.9-fold (0.28 log units) above what was measured, within the range that was stated.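

In this assay compound 3 gives 31300 nM, the only reading shown that is a number and not a limit. Putting 3,5-dimethylphenyl in place of 2-ethylphenyl on the amide-type nitrogen, with the same atoms joined differently, gives an at least 1.5-fold lower number from compound 2 to compound 3 (0.20 log units; that floor lies within the scatter), so this position may respond to how those atoms are arranged, but the step cannot yet be called a real change. The true step could be larger, but its size cannot be fixed, because compound 2 reads only as a limit: the limit of > 50000 nM in this assay, at which 2 of the 3 values shown sit.

As far as these compounds go, it remains open whether a different group on this nitrogen, such as a phenyl ring carrying an amine or a carboxylic acid, would move the number further. Also open, from the compounds shown here alone, is whether 3,5-dimethylphenyl would give a similar number on the core of compound 1.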